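Chloro to methyl on the outer ring: an expected effect

The source may report more compounds than this note shows. Statements on the series, on what has been measured and on what is new or still open speak of the compounds shown alone.

Measured so far:
compound 1, `CCOCCOC(=O)C(=O)Nc1nc(-c2cc(Cl)no2)cs1`, 6 mg/kg
compound 2, `CCOCCOC(=O)C(=O)Nc1nc(-c2cc(Br)no2)c(CC)s1`, 3 mg/kg

Both compounds were studied in a functional assay on the whole organism with Rattus norvegicus as the target; on this read-out lower numbers stand for an effect already at smaller amounts and higher numbers for an effect only at larger amounts of compound. In this assay compound 1 gives 6 mg/kg and compound 2 gives 3 mg/kg; these two numbers lie within the usual scatter of each other, so they cannot be told apart. Among the compounds with values here, compound 1 thus stands at one of two indistinguishable values, and there is no measured step to lean on.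

Compound 3, `CCOCCOC(=O)C(=O)Nc1nc(-c2cc(C)no2)cs1`, has not been measured. It differs from compound 1 in one place: methyl in place of chloro on an aromatic carbon. The exchanged group sits on the outer five-membered ring, away from the shared core that carries the amide and the ester chain.

Within the data shown here, with no comparable step among the measured compounds, the expectation rests on the smallness of the change alone, and a step of no more than the usual scatter, in either direction, is expected as no change at the digits printed from compound 1 to compound 3 (within the scatter). For compound 3 the value in this assay is therefore estimated at 6 mg/kg, with a range from 2.5 mg/kg to 15 mg/kg.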

Compound 3, dose for half-maximal effect: 0.04 mg/kg
Compound 3: middle estimate off by 150-fold (2.18 log units), on the high side; measured number outside the range, below it.
By their numbers in this assay, from the lowest: compound 3; then compounds 2 and 1 (each within the scatter of the next).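

This position, on an aromatic carbon of the five-membered ring and next to the ring nitrogen, proved highly sensitive to a very small exchange. In this assay the swap of chloro for methyl removes one heavy atom and adds one, with no ring, hydrogen-bond donor, hydrogen-bond acceptor or net charge on either side, yet it gives a 150-fold lower number from compound 1 to compound 3 (2.18 log units; beyond the scatter) and places compound 3 clearly apart from the other two compounds. Nothing available here explains why this one exchange has so large an effect, so the step stands as an observation without a cause.

Open, going by these compounds, is whether methyl is uniquely favourable here or whether a longer chain such as ethyl, an oxygen-linked group such as methoxy, or an amine would give a similarly low number at this place. Also open, on these data alone, is whether the same exchange would have a comparable effect in the bromo compound with its ethyl group on the shared core, since compound 2 differs from compound 3 in more than one place and offers no clean comparison.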